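The source may hold more compounds than are shown below. What is called first, only, known or untested is meant among the compounds shown, and "the series" means these compounds.

Measured compounds:
compound 1, `Nc1nc(N2CCN(C(=O)OCc3ccccc3)CC2)c2nc(-c3ccc(F)cc3)sc2n1`: 4900 nM in a functional assay on cells (Lymphocyte, Homo sapiens); a higher number here means a weaker inhibitor, a lower number a stronger inhibitor
compound 2, `CCCCCN1CCN(c2nc(N)nc3sc(-c4ccc(F)cc4)nc23)CC1`: > 10000 nM in this assay

Compound 2 stands at the edge of what this assay can report. The value given for compound 2 is a limit, not a number, and it sits at the limit of > 10000 nM in this assay, at which 1 of the 2 values shown sits. Compound 3, `Cc1cccc(N2CCN(c3nc(N)nc4sc(-c5ccc(F)cc5)nc34)CC2)c1`, differs from compound 2 by 3-methylphenyl in place of pentyl on an amine nitrogen in a ring. Among the measured compounds shown here, only one measured step touches this same ring nitrogen: an at least 2.0-fold higher number from compound 1 to compound 2 (0.30 log units; that floor lies within the scatter), a step that ended at the limit. For the measured compounds named here, it shows that swapping the group on this nitrogen can move the read-out, but it gives no measured foothold for a 3-methylphenyl there, since no compound with a group of that kind has a number. Compound 3 is therefore expected near 6000 nM, with a wide range from 1500 nM to 25000 nM, which means an expected step of an at least 1.6-fold lower number from compound 2 to compound 3 (0.22 log units; that floor lies within the scatter) that rests on little.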

Compound 3, half-maximal inhibitory concentration: > 10000 nM
Compound 3: a limit, no number; the forecaster's own chance of this, stated with the estimate: 40%; at least 1.6-fold (0.22 log units) between middle value and limit.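

In this assay compound 3 gives > 10000 nM, which is a limit and not a number. Putting 3-methylphenyl on this ring nitrogen in place of benzyloxycarbonyl gives an at least 2.0-fold higher number from compound 1 to compound 3 (0.30 log units; that floor lies within the scatter), so this step too has only a floor for its size, and that floor does not clear the usual scatter. What is new is that an aromatic ring on this nitrogen, like the pentyl chain of compound 2, gives no readable value, so two quite different groups now end in the same place: the limit of > 10000 nM in this assay, at which 2 of the 3 values shown sit.

With limits on both sides, the step between compound 2 and compound 3 cannot be read, and pentyl and 3-methylphenyl cannot be ranked. Still open, on these data alone, is whether a benzyl group, an acetyl group or a shorter carbamate such as ethoxycarbonyl on this nitrogen would give a measurable number.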